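A few compounds are considered here, and "the series" means these few. Any claim that something is new, unique, unknown or untested is made for them only; others in the source may bear on it.

Measured so far:
- compound 1 `CCCCCCCCCCCCNC(=O)[C@@H](NC(=O)c1cc2ccccc2o1)[C@@H](C)O`: 21300 nM
- compound 2 `CCCCCCCCCCCCNC(=O)[C@@H](NC(=O)/C=C/c1ccccc1)[C@@H](C)O`: 200000 nM

In a functional assay on SW-620 cells (Homo sapiens) for cytotoxicity, read by MTT assay, with a stated time of 48 h (a higher number here means a weaker inhibitor, a lower number a stronger inhibitor), compound 2 stands highest of the two numbers, the weaker of the pair, as the step of a 9.4-fold higher number from compound 1 to compound 2 (0.97 log units; beyond the scatter) shows. Compound 3 `C/C=C/C=C/C(=O)N[C@H](C(=O)NCCCCCCCCCCCC)[C@@H](C)O` differs from compound 2 by prop-1-en-1-yl in place of phenyl on a double-bonded chain carbon bound to a double-bonded chain carbon. Among the compounds with values here, the only measured step, a 9.4-fold higher number from compound 1 to compound 2 (0.97 log units; beyond the scatter), also reworked this acyl group, but it does not show what trimming the phenyl to a short chain does. With compound 2 already weak, the step of no change at the digits printed from compound 2 to compound 3 (within the scatter) is expected to stay within the scatter. Compound 3 is therefore estimated at 200000 nM, in the range 70000 nM to 600000 nM.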

Compound 3, half-maximal inhibitory concentration: 200000 nM
Compound 3: the middle estimate sits on the measured number at the digits printed, and the stated range covers the measured number.
By their numbers in this assay, from the lowest: compound 1; then compounds 2 and 3 (each within the scatter of the next).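

In this assay, putting prop-1-en-1-yl in place of phenyl on the double-bonded chain carbon gives no change at the digits printed from compound 2 to compound 3 (within the scatter), so at this position a six-membered aromatic ring and a short unsaturated chain cannot be told apart. The comparison with 1-benzofuran-2-yl now holds against a second group, with a 9.4-fold higher number from compound 1 to compound 3 (0.97 log units; beyond the scatter). No evidence is at hand on why the numbers fall this way. As far as these compounds go, what an amine or a carboxylic acid on the 1-benzofuran-2-yl group would do stays open, as does the effect of a longer chain in place of prop-1-en-1-yl.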